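The source may report more compounds than this note shows. Statements on the series, on what has been measured and on what is new or still open speak of the compounds shown alone.

In a functional assay on HT-1080 cells (Homo sapiens) for cytotoxicity, read by MTT assay, with a stated time of 72 h (a higher number here means a weaker inhibitor, a lower number a stronger inhibitor), three compounds on a shared core have been measured. Compound 1 (`COc1cccc(/C=C2\CCC/C(=C\c3cccc(Cl)c3)C2=O)c1OC`) gives 10300 nM in this series. For compound 2 (`COc1ccc(/C=C2\CCC/C(=C\c3cccc(OC)c3OC)C2=O)c(OC)c1`) the reading > 20000 nM is a limit of the assay and not a number. Compound 3 (`COc1ccc(/C=C2\CCC/C(=C\c3ccc(Br)cc3)C2=O)cc1OC`) gives 4300 nM as the lowest of the numbers, and its gap to compound 1 lies beyond the scatter. Compound 4 (`COc1ccc(/C=C2\CCC/C(=C\c3ccc(Cl)cc3Cl)C2=O)cc1OC`) carries 2,4-dichlorophenyl in place of 4-bromophenyl on a double-bonded chain carbon bound to a double-bonded ring carbon. Among the compounds with values here, no measured pair differs in one place only, so the expectation in this assay rests on compound 3 at 4300 nM and points to no shift beyond the scatter. The expected change is a 1.2-fold higher number from compound 3 to compound 4 (0.07 log units; within the scatter) in size. Compound 4 is estimated at 5000 nM within an expected range from 2000 nM to 13000 nM.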

Compound 4, half-maximal inhibitory concentration: 10500 nM
Beside the measured number, compound 4's estimate is 2.1-fold (0.32 log units) below it; low and high end bracket the measured number.
By their numbers in this assay, from the lowest: compound 3; then compounds 1 and 4 (each within the scatter of the next). At a limit, above all of these: compound 2.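

In this assay, within the data shown here, this is the first pair that differs in one place only, and it shows that the group on a double-bonded chain carbon bound to a double-bonded ring carbon can move the reading on its own. Putting 2,4-dichlorophenyl in place of 4-bromophenyl gives a 2.4-fold higher number from compound 3 to compound 4 (0.39 log units; beyond the scatter) in a modest step. Nothing measured here bears on the cause of this step.

A single pair cannot separate the loss of bromine from the entry of two chlorine atoms. On these data alone, how an amine or a carboxylic acid on this phenyl ring would read remains open.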